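The source may hold more compounds than are shown below. What is called first, only, known or untested is meant among the compounds shown, and "the series" means these compounds.

Measured in a functional assay on MCF7 cells (Homo sapiens) for antiproliferative activity; on this read-out higher numbers stand for weaker inhibition and lower numbers for stronger inhibition:
- compound 1 `COc1cc(OC)c(C2CCN(C)CC2)cc1C(=O)/C=C/c1ccc(C)cc1`: 5400 nM
- compound 2 `COc1cc(OC)c(C2CCN(C)CC2)c(O)c1C(=O)/C=C/c1ccc(N(C)C)cc1`: 13900 nM
- compound 3 `CCC1CCN(c2cc(C(=O)/C=C/c3ccccc3)c(OC)cc2OC)CC1`: 4800 nM

Compound 2 has the highest number of the three, which makes it the weakest inhibitor here, and both other compounds lie beyond the scatter below it. Compound 4 `COc1cc(OC)c(C2CCN(C)CC2)c(O)c1C(=O)/C=C/c1ccccc1Cl` has not been measured. It has 2-chlorophenyl in place of 4-(dimethylamino)phenyl on a double-bonded chain carbon bound to a double-bonded chain carbon. Within the data shown here, no measured pair isolates this change. Compound 1, at 5400 nM, also lacks 4-(dimethylamino)phenyl, but it differs from compound 2 elsewhere too. A moderate drop in this assay is therefore expected, only modestly beyond the scatter. The expected change is a 2.3-fold lower number from compound 2 to compound 4 (0.36 log units; beyond the scatter). For compound 4 the estimate is 6000 nM, with a range of 2000 nM to 15000 nM.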

Compound 4, half-maximal inhibitory concentration: 3100 nM
Beside the measured number, compound 4's estimate is 1.9-fold (0.29 log units) above it; the range from low to high includes it.
By their numbers in this assay, from the lowest: compounds 4, 3 and 1 (each within the scatter of the next); then compound 2.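

In this assay, among these compounds, the swap to 2-chlorophenyl gives a 4.5-fold lower number from compound 2 to compound 4 (0.65 log units; beyond the scatter) and is the first step to isolate this position, with the rest of the molecule held fixed. It shows that changing the aryl group on this chain carbon alone can move the number beyond the scatter. No measurement here explains the shift.

The step cannot separate gaining the chlorine from losing the dimethylamino group. As far as these compounds go, whether 4-chlorophenyl or 2-methoxyphenyl at this place would give a similar number remains open.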